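This account rests on a few compounds, and the source may have more. Where it says the series, first, only, none or still open, it means among the compounds named here.

Measured so far in a functional assay on MGC-803 cells (Homo sapiens) for cytotoxicity, read by MTT assay, with a stated time of 38 h; on this read-out lower numbers stand for stronger inhibition and higher numbers for weaker inhibition:
- compound 1 `COc1cc(OC)c2c(=O)c(OCC(=O)N/N=C/c3sccc3C)c(-c3cc(OC)c(OC)c(OC)c3)oc2c1`: 7740 nM
- compound 2 `COc1cc(OC)c2c(=O)c(OCCCCN3CCCC3)c(-c3cc(OC)c(OC)c(OC)c3)oc2c1`: 18600 nM
- compound 3 `COc1cc(OC)c2c(=O)c(OCC(=O)N/N=C/c3ccccc3F)c(-c3cc(OC)c(OC)c(OC)c3)oc2c1`: 2780 nM

Compound 3 holds the lowest of the three numbers, with a 2.8-fold lower number from compound 1 to compound 3 (0.44 log units; beyond the scatter) and a 6.7-fold lower number from compound 2 to compound 3 (0.83 log units; beyond the scatter). The next compound is compound 4 `COc1cc(OC)c2c(=O)c(OCC(=O)N/N=C/c3ccc[nH]3)c(-c3cc(OC)c(OC)c(OC)c3)oc2c1`, which is not yet measured in this assay. It differs from compound 3 as follows: 1H-pyrrol-2-yl in place of 2-fluorophenyl on a carbon with a double bond to nitrogen. In words, this is 1H-pyrrol-2-yl in place of 2-fluorophenyl on a carbon with a double bond to nitrogen.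

Going by the values given here, only one measured step changes this same group, a 2.8-fold lower number from compound 1 to compound 3 (0.44 log units; beyond the scatter), where 2-fluorophenyl replaces 3-methylthiophen-2-yl. The other two steps, a 2.4-fold higher number from compound 1 to compound 2 (0.38 log units; beyond the scatter) and a 6.7-fold lower number from compound 2 to compound 3 (0.83 log units; beyond the scatter), exchange the whole chain and bear on this change only weakly. Among the compounds with values here, no compound with 1H-pyrrol-2-yl has been measured, so the closest guide is compound 1 at 7740 nM, which also carries a five-membered aromatic ring at this place. A modest rise is therefore expected, as a 2.2-fold higher number from compound 3 to compound 4 (0.33 log units; beyond the scatter). For compound 4 the estimated value is 6000 nM, with an expected range from 2200 nM to 16000 nM.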

Compound 4, half-maximal inhibitory concentration: 5610 nM
Compound 4: middle estimate off by 1.1-fold (0.03 log units), on the high side; the measured number falls inside the stated range.
By their numbers in this assay, from the lowest: compounds 3, 4 and 1 (each within the scatter of the next, the first and the last beyond it); then compound 2.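

In this assay, 1H-pyrrol-2-yl on a carbon with a double bond to nitrogen gives a 2.0-fold higher number from compound 3 to compound 4 (0.30 log units; within the scatter) when it replaces 2-fluorophenyl and a 1.4-fold lower number from compound 1 to compound 4 (0.14 log units; within the scatter) when it replaces 3-methylthiophen-2-yl, so it cannot be separated from either group even though those two differ in a 2.8-fold lower number from compound 1 to compound 3 (0.44 log units; beyond the scatter) in this series. The exchange of the whole chain gives a 3.3-fold lower number from compound 2 to compound 4 (0.52 log units; beyond the scatter) and so keeps compound 4 apart from compound 2, as compound 1 and compound 3 also are. No evidence on the cause of these differences accompanies the numbers.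

Open, as far as these compounds go, is whether a plain phenyl, a pyridine ring or a pyrrole carrying methyl on its nitrogen at this place would stay in the same band. Also open, from the compounds shown here alone, is whether an amine or a carboxylic acid on this ring would move the number beyond that band.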